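Pyrimidinyl amide swap carried onto the dimethylamino core

A few compounds are considered here, and "the series" means these few. Any claim that something is new, unique, unknown or untested is made for them only; others in the source may bear on it.

Compound 1 `COc1cc(N(C)CCN(C)C)c(NC(=O)c2ccncn2)cc1Nc1nccc(-c2cn(C)c3ccccc23)n1` carries a pyrimidin-4-yl amide. In a functional assay on NCI-H1975 cells (Homo sapiens) for antiproliferative activity, read by MTT assay, with a stated time of 72 h (on this read-out higher numbers stand for weaker inhibition and lower numbers for stronger inhibition), compound 1 gives 1560 nM. Compound 2 `COc1cc(N(C)CCN(C)C)c(NC(=O)c2ncccn2)cc1Nc1nccc(-c2cn(C)c3ccccc23)n1` differs from it by pyrimidin-2-yl in place of pyrimidin-4-yl on a carbonyl carbon and in this assay compound 2 gives 650 nM; the swap made a 2.4-fold lower number from compound 1 to compound 2 (0.38 log units; beyond the scatter). Compound 3 `COc1cc(N(C)C)c(NC(=O)c2ccncn2)cc1Nc1nccc(-c2cn(C)c3ccccc23)n1` rests on a different core, differing from compound 1 by hydrogen in place of (dimethylamino)methyl on a saturated chain carbon bound to a nitrogen on an aromatic ring, and in this assay compound 3 gives 1250 nM; that core change made a 1.2-fold lower number from compound 1 to compound 3 (0.10 log units; within the scatter). Compound 4 `COc1cc(N(C)C)c(NC(=O)c2ncccn2)cc1Nc1nccc(-c2cn(C)c3ccccc23)n1` has not yet been measured in this assay. It differs from compound 3 by pyrimidin-2-yl in place of pyrimidin-4-yl on a carbonyl carbon; the place of the change reads word for word as in the change from compound 1 to compound 2, so this is the same change carried onto the second core. Going by the values given here, because the core change made only a 1.2-fold lower number from compound 1 to compound 3 (0.10 log units; within the scatter), the amide swap is expected to behave alike on both cores, and a step of a 2.3-fold lower number from compound 3 to compound 4 (0.36 log units; beyond the scatter) is expected, resting on the single measured instance a 2.4-fold lower number from compound 1 to compound 2 (0.38 log units; beyond the scatter). Compound 4 is thus expected to give 550 nM in this assay, estimated to fall between 250 nM and 1200 nM.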

Compound 4, half-maximal inhibitory concentration: 5400 nM
Compound 4: the middle estimate sits 9.8-fold (0.99 log units) below what was measured, and the stated range ends below it.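

In this assay the swap of pyrimidin-4-yl for pyrimidin-2-yl on the carbonyl carbon does not carry from the core of compound 1 to the core of compound 3, where it gives a 4.3-fold higher number from compound 3 to compound 4 (0.64 log units; beyond the scatter) and so runs opposite to the step on the first core: the same change on two cores in this assay, a 2.4-fold lower number (0.38 log units; beyond the scatter) from compound 1 to compound 2 and a 4.3-fold higher number (0.64 log units; beyond the scatter) from compound 3 to compound 4, 10-fold (1.02 log units) apart, beyond the scatter of two such steps

Read along the other edge, the loss of (dimethylamino)methyl from the saturated chain gives an 8.3-fold higher number from compound 2 to compound 4 (0.92 log units; beyond the scatter), although the same loss with the pyrimidin-4-yl amide stayed within the scatter: the same change on two cores in this assay, a 1.2-fold lower number (0.10 log units; within the scatter) from compound 1 to compound 3 and an 8.3-fold higher number (0.92 log units; beyond the scatter) from compound 2 to compound 4, 10-fold (1.02 log units) apart, beyond the scatter of two such steps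

The amide swap and the chain change are therefore not additive in these four compounds, so a step measured on one core did not predict the other here, but this single set of four does not show why or how widely this holds.

Still open, going by these compounds, is whether the reversal is specific to pyrimidin-2-yl or recurs with another amide group, such as pyridin-2-yl. A longer chain, such as a dimethylaminopropyl group, could show whether the step on the first core persists.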